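Ethyl on the benzyl ring: cytotoxicity working notes

The source may report more compounds than this note shows. Statements on the series, on what has been measured and on what is new or still open speak of the compounds shown alone.

Measured so far in an ADME assay on HEK293 cells (Homo sapiens) for cytotoxicity, read by resazurin assay, with a stated time of 72 h; a higher number here means that more compound is tolerated, a lower number that less compound is tolerated:
compound 1, `O=C(O)c1ccc(CCOc2c(F)ccc3nc(C(=O)NCc4ccccc4)[nH]c(=O)c23)cc1`, gives > 20000 nM, which is a limit of the assay and not a number.
compound 2, `CCc1cccc(CNC(=O)c2nc3ccc(F)c(OCCc4ccc(C(=O)O)cc4)c3c(=O)[nH]2)c1`, gives > 20000 nM, again a limit.
compound 3, `O=C(O)c1ccc(COCc2cccc3nc(C(=O)NCc4ccccc4)[nH]c(=O)c23)cc1`, gives > 20000 nM, also a limit.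

In this assay the step from compound 1 to compound 2 is a step that the two limits leave unreadable from compound 1 to compound 2; the change behind it is ethyl in place of hydrogen on an aromatic carbon. How the core of compound 1 differs from the core of compound 3 is not broken down here.

Compound 4, `CCc1ccc(CNC(=O)c2nc3cccc(COCc4ccc(C(=O)O)cc4)c3c(=O)[nH]2)cc1`, is not yet measured. It differs from compound 3 by ethyl in place of hydrogen on an aromatic carbon. This is the same kind of change as from compound 1 to compound 2, not the same: there the ethyl sits meta to a large group, here para to a large group.

Among the measured compounds shown here, all three compounds so far share (the limit of > 20000 nM in this assay, at which 3 of the 3 values shown sit). On that basis, and on the unreadable step from compound 1 to compound 2, the step from compound 3 to compound 4 in this assay is expected to be a step that the limit leaves unreadable from compound 3 to compound 4. Compound 4 is expected to give 30000 nM, between 15000 nM and 80000 nM, most likely reported once more as a limit.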

Compound 4, half-maximal cytotoxic concentration: > 20000 nM
Compound 4: no number, only a limit (the forecaster's own chance of this, stated with the estimate: 85%); the middle value is on the limit's open side.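

In this assay compound 3 and compound 4 both stand only as limits, so no step can be read between them. The compounds shown leave open whether ethyl in place of hydrogen changes the tolerated concentration at all, and at what concentration any of them becomes cytotoxic, with every value resting on one limit: the limit of > 20000 nM in this assay, at which 4 of the 4 values shown sit.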